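The compounds below may be only part of what the source reports. "The series", "measured", "known", "first", "only" and "open" are said of these compounds alone.

Of the compounds shown here, three have been measured in an assay on T-REx-293 cells for inhibition of potassium channel subfamily T member 1 (Homo sapiens), read by patch clamp; a higher number here means a weaker inhibitor, a lower number a stronger inhibitor. Compound 1 `C[C@H](NC(=O)c1cc(C2CC2)nn1C)c1nc(-c2ccccc2)no1` gives 11400 nM in this assay. Compound 2 `Cc1cccc(-c2nnc([C@H](C)NC(=O)c3cc(C4CC4)nn3C)o2)c1` reaches only the limit of the assay, recorded as > 30000 nM, so no number is known for it. Compound 3 `Cc1cc(-c2noc([C@H](C)NC(=O)c3cc(C(F)(F)F)nn3C)n2)ccn1` gives 165 nM in this assay, the lowest of the two numbers available; the nearest, compound 1, sits at a figure that is far higher, well beyond the usual scatter. One of the three results, that for compound 2, is a limit rather than a number (the limit of > 30000 nM in this assay, at which 1 of the 3 values shown sits). Compound 1 and compound 3 differ in more than one place, so their two values are simply what they are.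

Compound 4 `CO[C@@H](C)c1cc(-c2noc([C@H](C)NC(=O)c3cc(C(F)(F)F)nn3C)n2)ccn1` has not yet been measured. It differs from compound 3 in one place: 1-methoxyethyl in place of methyl on an aromatic carbon.

Among the compounds with values here, no measured pair differing in just one place exists here, so there is no step to lean on. The change is small in size and adds one hydrogen-bond acceptor, and the expected step in this assay a 1.5-fold higher number from compound 3 to compound 4 (0.18 log units; within the scatter) is a modest one, within or close to the scatter, with no clear direction beyond it. Compound 4 is therefore expected to give about 250 nM in this assay, with a likely range from 60 nM to 1000 nM.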

Compound 4, half-maximal inhibitory concentration: 744 nM
Beside the measured number, compound 4's estimate is 3.0-fold (0.47 log units) below it, within the range that was stated.
By their numbers in this assay, from the lowest: compound 3; then compound 4; then compound 1. At a limit, above all of these: compound 2.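

In this assay, within the data shown here, the pair gives the first comparison between two compounds that differ in one place, a 4.5-fold higher number from compound 3 to compound 4 (0.65 log units; beyond the scatter), and it shows that inhibition responds to what sits on this aromatic carbon next to the ring nitrogen. Replacing methyl with 1-methoxyethyl, which adds a hydrogen-bond acceptor and a defined stereocentre, weakens inhibition but does not remove it, as compound 4 gives 744 nM in this assay and remains a measurable inhibitor. Nothing measured for these compounds explains why this replacement gives the weaker inhibitor.

Still open, going by these compounds, is whether the oxygen or the larger carbon chain accounts for the step, which an isopropyl group, with a branched carbon chain and no oxygen, could help to separate. Also open, on these data alone, are how the opposite stereocentre of 1-methoxyethyl or a dimethylamino group would compare at this position, and whether the same replacement would give a step of similar size on a different core.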